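The compounds below may be only part of what the source reports. "The series", "measured", "known", "first", "only" and "open" are said of these compounds alone.

Measured in a functional assay on PC-3 cells (Homo sapiens) for cytotoxicity, read by MTT assay, with a stated time of 48 h; on this read-out higher numbers stand for weaker inhibition and lower numbers for stronger inhibition: compound 1 `CCN(CC)CC(=O)N1N=C(C)CC1c1ccccc1OC(C)=O` gives 51200 nM; compound 2 `CC(=O)Oc1ccccc1C1CC(C)=NN1C(=O)CN(C(C)C)C(C)C` gives 24500 nM.

Compound 2 thus stands at the lower of the two numbers, set apart by the step of a 2.1-fold lower number from compound 1 to compound 2 (0.32 log units; beyond the scatter). Compound 3 `CC(=O)Oc1ccccc1C1CC(C)=NN1C(=O)CN1CCCCC1` differs from compound 2 by piperidin-1-yl in place of diisopropylamino on a saturated chain carbon bound to a carbonyl carbon. Going by the values given here, no measured step covers a ring amine in this position; the only comparable step, from compound 1 to compound 2, exchanged one open-chain amine for another and was modest. The estimated step of a 1.2-fold higher number from compound 2 to compound 3 (0.09 log units; within the scatter) is therefore expected to stay within the scatter. Compound 3 is expected at about 30000 nM, within 12000 nM to 80000 nM.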

Compound 3, half-maximal inhibitory concentration: 4070 nM
The estimate for compound 3 lay 7.4-fold (0.87 log units) above the measured number; the measured number lies below the stated range.
By their numbers in this assay, from the lowest: compound 3; then compound 2; then compound 1.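

In this assay the amine on a saturated chain carbon bound to a carbonyl carbon proves far more influential than the earlier pair suggested: piperidin-1-yl gives a 6.0-fold lower number from compound 2 to compound 3 (0.78 log units; beyond the scatter) and also a 13-fold lower number from compound 1 to compound 3 (1.10 log units; beyond the scatter). Both steps are larger than the exchange of one open-chain amine for another, a 2.1-fold lower number from compound 1 to compound 2 (0.32 log units; beyond the scatter), and compound 3 has the lowest number of the three. Nothing available here explains this difference. Going by these compounds, it remains open whether the lower number follows from having any ring amine here or from piperidin-1-yl specifically; pyrrolidin-1-yl or morpholin-4-yl in the same place would help to separate the two.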